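The compounds below may be only part of what the source reports. "The series", "measured", "known", "first", "only" and "open" are said of these compounds alone.

Compound 1 `CN(C(=O)NC(=O)c1ccccc1F)c1nc(C(F)(F)F)c(C(=O)N/N=C/c2ccc(C(F)(F)F)cc2)s1`: 3.97 ug/mL in a functional assay on HeLa cells (Homo sapiens) for inhibition, read by MTT assay, with a stated time of 72 h; on this read-out lower numbers stand for stronger inhibition and higher numbers for weaker inhibition
Compound 2 `CN(C(=O)NC(=O)c1ccc(Cl)cc1Cl)c1nc(C(F)(F)F)c(C(=O)N/N=C/c2ccc(C(F)(F)F)cc2)s1`: 7.99 ug/mL in this assay
Compound 3 `CN(C(=O)NC(=O)c1cccc([N+](=O)[O-])c1)c1nc(C(F)(F)F)c(C(=O)N/N=C/c2ccccc2C(F)(F)F)s1`: 4.15 ug/mL in this assay

In this assay compound 2 gives 7.99 ug/mL, the highest of the three numbers, yet its gaps to compound 3 and to compound 1 both fall within the scatter, so no order among the three is claimed. Compound 4 `CN(C(=O)NC(=O)c1ccc(F)c(F)c1)c1nc(C(F)(F)F)c(C(=O)N/N=C/c2ccc(C(F)(F)F)cc2)s1` has not yet been measured; it differs from compound 2 in one place: 3,4-difluorophenyl in place of 2,4-dichlorophenyl on a carbonyl carbon. Going by the values given here, the only measured step at that place is a 2.0-fold higher number from compound 1 to compound 2 (0.30 log units; within the scatter), which also replaced the group on that carbonyl carbon and stayed within the scatter. Among the compounds with values here, compound 3 differs from compound 2 in more than one place and offers no step that bears directly. With one neutral precedent at the same place and nothing pointing either way, the change to compound 4 is expected to leave the number in the same band as compounds 1 and 2. The implied step a 1.6-fold lower number from compound 2 to compound 4 (0.20 log units; within the scatter) is expected to stay within the scatter. Compound 4 is estimated at 5 ug/mL, in the range 2.5 ug/mL to 10 ug/mL.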

Compound 4, half-maximal inhibitory concentration: 5.1 ug/mL
Estimate against measurement, compound 4: 1.0-fold (0.01 log units) below; the range from low to high includes it.
By their numbers in this assay, from the lowest: compounds 1, 3, 4 and 2 (each within the scatter of the next).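

The aryl group on the carbonyl carbon now has three variants on an otherwise identical structure: 2-fluorophenyl, 2,4-dichlorophenyl and 3,4-difluorophenyl. In this assay the two new steps (a 1.6-fold lower number from compound 2 to compound 4 (0.19 log units; within the scatter)) and (a 1.3-fold higher number from compound 1 to compound 4 (0.11 log units; within the scatter)) stay within the scatter, so neither replacing both chlorines with fluorines in a different arrangement nor going from one fluorine to two in a different arrangement gives a readable difference. The kind, number and arrangement of halogens tried so far therefore set no order among compound 1, compound 2 and compound 4.

As far as these compounds go, all three groups are halogen-bearing phenyl rings, so it remains open whether a phenyl ring carrying an amine or a carboxylic acid at this place, or a cyclohexyl group in place of the ring, would stay in the same band. No measurement shown here accounts for these numbers.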